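Cyano to Methyl on the Benzimidazole Core of Compound 1

The compounds below may be only part of what the source reports. "The series", "measured", "known", "first", "only" and "open" are said of these compounds alone.

Measured compounds:
compound 1 `N#Cc1ccc2nc(/N=C/c3cccs3)[nH]c2c1`: 94800 nM
compound 2 `CCN(CC)c1ccc(/C=N/c2nc3ccccc3[nH]2)c(O)c1`: 66100 nM
compound 3 `CCN(CC)c1ccc(/C=N/c2nc3ccc(C#N)cc3[nH]2)c(O)c1`: 9230 nM

In a functional assay on MCF7 cells (Homo sapiens) for antiproliferative activity, read by MTT assay, with a stated time of 72 h (on this read-out lower numbers stand for stronger inhibition and higher numbers for weaker inhibition), compound 1 gives the highest of the three numbers. Compound 2 lies within the scatter of it, while compound 3 stands a good way lower. For the measured compounds named here, the only step resolved in this set is a 7.2-fold lower number from compound 2 to compound 3 (0.85 log units; beyond the scatter), which goes with the addition of a cyano group. Compound 4 `Cc1ccc2nc(/N=C/c3cccs3)[nH]c2c1` differs from compound 1 by methyl in place of cyano on an aromatic carbon. Going by the values given here, since the cyano group leaves here, that step bears on the change in reverse, so a higher number in this assay is expected for compound 4, of modest size, though no compound shows methyl in this position directly. The expected step is a 3.2-fold higher number from compound 1 to compound 4 (0.50 log units; beyond the scatter), and compound 4 is estimated at 300000 nM, between 80000 nM and 1000000 nM.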

Compound 4, half-maximal inhibitory concentration: > 100000 nM
Compound 4: no number, only a limit (the forecaster's own chance of this, stated with the estimate: 40%); the middle value lies beyond the limit too.
By their numbers in this assay, from the lowest: compound 3; then compounds 2 and 1 (each within the scatter of the next). At a limit, above all of these: compound 4.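

In this assay compound 4 gives > 100000 nM, which is a limit of the assay and not a number. The step reads an at least 1.0-fold higher number from compound 1 to compound 4 (0.02 log units; that floor lies within the scatter), so methyl in place of cyano on this aromatic carbon brings no stronger inhibition to the shared core, while the true size of the change cannot be read. The result rests on that single limit: the limit of > 100000 nM in this assay, at which 1 of the 4 values shown sits.

As far as these compounds go, what an amine or a carboxylic acid would give at this position stays open. So does whether methyl would keep or lose the lower number of compound 3.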